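The source may hold more compounds than are shown below. What is called first, only, known or untested is meant among the compounds shown, and "the series" means these compounds.

Compound 2 `CSc1nc(NCc2ccc(-c3ccccn3)cc2)c2[nH]nc(C(C)C)c2n1` gives the highest number of the three compounds in a functional assay on HT cells (Homo sapiens) for antiproliferative activity, read by fluorescence, with a stated time of 72 h (a higher number here means a weaker inhibitor of growth, a lower number a stronger inhibitor of growth), with a value of 783 nM; compound 1 `CC(C)c1n[nH]c2c(NCc3ccc(-c4ccccn4)cc3)nc(SCC(O)C(F)(F)F)nc12` gives 690 nM and compound 3 `CC(C)c1n[nH]c2c(NCc3ccc(-c4ccccn4)cc3)nc(SCCn3ccnc3)nc12` gives 155 nM. Compound 4 `CC(C)c1n[nH]c2c(NCc3ccc(-c4ccccn4)cc3)nc(SCC(C)(C)N)nc12` differs from compound 2 by 1-amino-1-methylethyl in place of hydrogen on a saturated chain carbon bound to a sulfur. Among the measured compounds shown here, two measured steps bear on this position on the chain: a 1.1-fold higher number from compound 1 to compound 2 (0.05 log units; within the scatter) and a 5.1-fold lower number from compound 2 to compound 3 (0.70 log units; beyond the scatter). One extension at that carbon left the number unchanged, the other lowered it modestly, so an added group here has so far not raised the number. For compound 4 a modest lowering is expected, a 2.1-fold lower number from compound 2 to compound 4 (0.31 log units; beyond the scatter), though no beyond-scatter change would also be unsurprising. Compound 4 is therefore estimated at 380 nM, within a range of 150 nM to 950 nM.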

Compound 4, concentration for 50% growth inhibition: 85 nM
Estimate against measurement, compound 4: 4.5-fold (0.65 log units) above; the whole stated range lies above it.
By their numbers in this assay, from the lowest: compounds 4 and 3 (each within the scatter of the next); then compounds 1 and 2 (each within the scatter of the next).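

In this assay, 1-amino-1-methylethyl in place of hydrogen on a saturated chain carbon bound to a sulfur gives a 9.2-fold lower number from compound 2 to compound 4 (0.96 log units; beyond the scatter), showing that a group with no ring can also lower the number beyond the scatter. The change from the 2,2,2-trifluoro-1-hydroxyethyl group gives an 8.1-fold lower number from compound 1 to compound 4 (0.91 log units; beyond the scatter), so compound 1 remains the one extension without such a lowering. The step of a 1.8-fold lower number from compound 3 to compound 4 (0.26 log units; within the scatter) places the two lowering groups within the scatter of each other.

Nothing available here explains these differences. On these data alone, whether a 2-methylpropyl group without the amine, or a carboxylic acid at this place, would give a number like that of compound 4 remains open.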